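The source may hold more compounds than are shown below. What is called first, only, known or untested is meant among the compounds shown, and "the series" means these compounds.

Measured in a functional assay on A549 cells (Homo sapiens) for cytotoxicity, read by MTT assay, with a stated time of 72 h; on this read-out lower numbers stand for stronger inhibition and higher numbers for weaker inhibition:
Compound 1 `COc1cccc(/C=C2\CCC/C(=C\c3ccc(Br)cc3)C2=O)c1OC`: > 20000 nM (a limit)
Compound 2 `COc1cccc(/C=C2\CCC/C(=C\c3cc(Cl)cc(Cl)c3)C2=O)c1OC`: 12500 nM
Compound 3 `COc1ccc(/C=C2\CCC/C(=C\c3ccccc3Br)C2=O)cc1OC`: > 20000 nM (a limit)

For compound 3 the entry > 20000 nM is a limit of this assay and not a measured number. Compound 3 therefore stands at the limit of > 20000 nM in this assay, at which 2 of the 3 values shown sit.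

Compound 4 `COc1ccc(/C=C2\CCC/C(=C\c3cccc(Cl)c3Cl)C2=O)cc1OC` differs from compound 3 in a single group, with 2,3-dichlorophenyl in place of 2-bromophenyl on a double-bonded chain carbon bound to a double-bonded ring carbon. The rest of the structure stays the same.

Within the data shown here, one measured step bears on this change, because it also exchanges a bromine-carrying phenyl group for a dichlorophenyl group: an at least 1.6-fold lower number from compound 1 to compound 2 (0.20 log units; that floor lies within the scatter). This is weak guidance. Its size is only a floor, the two dichlorophenyl groups are not the same, and compound 1 and compound 2 also differ from compound 3 elsewhere in the structure. It does suggest a modest move toward a lower number, and no more than that can be expected.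

The expected change is an at least 1.3-fold lower number from compound 3 to compound 4 (0.12 log units; that floor lies within the scatter), and another limit would be no surprise. The estimate for compound 4 is 15000 nM, with an expected range of 6000 nM to 30000 nM.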

Compound 4, half-maximal inhibitory concentration: > 20000 nM
Compound 4: only a limit was reported; the forecaster's own chance of this, stated with the estimate: 50%; middle value at least 1.3-fold (0.12 log units) from the limit.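

In this assay, compound 3 and compound 4 both sit at a limit and not at a measured number, so the step between them cannot be read. The compounds shown leave open whether 2,3-dichlorophenyl in place of 2-bromophenyl changes the read-out at all, with most values resting at the same point: the limit of > 20000 nM in this assay, at which 3 of the 4 values shown sit.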